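Trifluoromethyl for methylsulfanyl: a step in cytotoxicity

The source may report more compounds than this note shows. Statements on the series, on what has been measured and on what is new or still open speak of the compounds shown alone.

Measured so far in an ADME assay on MDCK cells (Canis lupus familiaris) for cytotoxicity; on this read-out lower numbers stand for higher toxicity in this test and higher numbers for lower toxicity in this test:
- compound 1 `CSc1nc2n(n1)C(O)C([N+](=O)[O-])=NN2` gives 99000 nM
- compound 2 `O=[N+]([O-])C1=CNc2ncnn2C1c1ccc(O)c(O)c1` gives 368000 nM
- compound 3 `O=[N+]([O-])C1=NNc2nc(C(F)(F)F)nn2C1c1c(O)cc(O)cc1O` gives 252000 nM

Compound 1 has the lowest number of the three, and its gap to each of the others lies beyond the usual scatter. Compound 4 `O=[N+]([O-])C1=NNc2nc(C(F)(F)F)nn2C1O` has not yet been measured. It carries trifluoromethyl in place of methylsulfanyl on an aromatic carbon. Within the data shown here, no measured pair shows this change alone. Among the measured compounds shown here, compound 3, the only measured compound with trifluoromethyl, gives 252000 nM as its number, but it differs from compound 4 elsewhere as well. In this assay a moderate rise is therefore expected (a 1.9-fold higher number from compound 1 to compound 4 (0.28 log units; within the scatter)). For compound 4 the estimated value is 190000 nM (range 80000 nM to 420000 nM).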

Compound 4, half-maximal cytotoxic concentration: 40000 nM
Compound 4: the middle estimate sits 4.8-fold (0.68 log units) above what was measured, and the stated range ends above it.
By their numbers in this assay, from the lowest: compound 4; then compound 1; then compounds 3 and 2 (each within the scatter of the next).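

In this assay, trifluoromethyl in place of methylsulfanyl on this aromatic carbon now has a step of its own, a 2.5-fold lower number from compound 1 to compound 4 (0.39 log units; beyond the scatter), which places the change on the side of higher toxicity in this test. Compound 3, which differs from compound 4 elsewhere as well, could not show this. Nothing at hand accounts for the step. From the compounds shown here alone, whether an amine or a longer chain on this carbon would give a lower or a higher number stays open, and so does whether the same change gives a similar step in compounds carrying the substituted phenyl ring of compound 3.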